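Extending the amine chain on a cyclohexene triol core

The source may hold more compounds than are shown below. What is called first, only, known or untested is meant among the compounds shown, and "the series" means these compounds.

Measured in an assay for inhibition of beta-galactosidase (Homo sapiens), read by fluorescence, with a stated time of 30 min, at pH 4.5; a lower number here means a stronger inhibitor, a higher number a weaker inhibitor:
Compound 1, `CCCCCCCCN[C@@H]1C=C(C)[C@H](O)[C@H](O)[C@H]1O`, gives 46000 nM.
Compound 2, `CCCCN[C@@H]1C=C[C@H](O)[C@H](O)[C@H]1O`, gives 50000 nM.
Compound 3, `CCCCCN[C@@H]1C=C[C@H](O)[C@H](O)[C@H]1O`, gives 19000 nM.

Compound 3 holds the lowest number of the three in this assay; the nearest is compound 1 and the furthest compound 2, both beyond the scatter. Compound 4, `CCCCCCCCCCN[C@@H]1C=C[C@H](O)[C@H](O)[C@H]1O`, differs from compound 3 by pentyl in place of hydrogen on a saturated chain carbon, five bonds along the chain from an amine nitrogen. Within the data shown here, one measured step bears on this change: a 2.6-fold lower number from compound 2 to compound 3 (0.42 log units; beyond the scatter). That step lengthened the chain by one carbon; the present change adds five more, and compound 1, carrying an octyl chain together with a methyl on the ring, sits between compound 2 and compound 3 rather than below them, so the effect of further lengthening is unclear. Among the measured compounds shown here, on the single relevant step, compound 4 is expected to lie somewhat lower than compound 3, a 1.6-fold lower number from compound 3 to compound 4 (0.20 log units; within the scatter), with wide uncertainty. The estimate for compound 4 in this assay is 12000 nM, within 3000 nM to 45000 nM.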

Compound 4, half-maximal inhibitory concentration: 43000 nM
The estimate for compound 4 lay 3.6-fold (0.55 log units) below the measured number; the range from low to high includes it.
By their numbers in this assay, from the lowest: compound 3; then compounds 4, 1 and 2 (each within the scatter of the next).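

Adding pentyl on a saturated chain carbon, five bonds along the chain from an amine nitrogen, runs against the earlier lengthening: in this assay it gives a 2.3-fold higher number from compound 3 to compound 4 (0.35 log units; beyond the scatter) and shows that the number does not keep falling as the chain grows. Among these compounds, compound 4 and compound 2 stand level, with a 1.2-fold lower number from compound 2 to compound 4 (0.07 log units; within the scatter) here, so of these three chains on the shared core only that of compound 3 stands apart. Nothing available accounts for this turn.

Where the number turns upward remains open, as a hexyl or octyl chain on the core of compound 3 is not among the compounds shown. Also open, going by these compounds, is whether a phenyl or a hydroxyl at the end of the longer chain would change this picture.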